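Furan-2-yl Replaces the Phenol on the Hydrazone Carbon

The source may hold more compounds than are shown below. What is called first, only, known or untested is meant among the compounds shown, and "the series" means these compounds.

For the measured compounds named here, compound 2 `Cc1ccc(O)c(/C=N\NC(=O)c2oc3cccc(O)c3c2C)c1` gives 7350 nM in a functional assay on PC-3 cells (Homo sapiens) for inhibition (a higher number here means a weaker inhibitor, a lower number a stronger inhibitor), the lowest of the two numbers so far, though compound 1 `Cc1c(C(=O)N/N=C\c2cccc(F)c2O)oc2cccc(O)c12` with 12700 nM lies within the scatter of it, as a 1.7-fold lower number from compound 1 to compound 2 (0.24 log units; within the scatter) shows. Compound 3 `Cc1c(C(=O)N/N=C\c2ccco2)oc2cccc(O)c12` carries furan-2-yl in place of 2-hydroxy-5-methylphenyl on a carbon with a double bond to nitrogen. Going by the values given here, the only measured step at this position, a 1.7-fold lower number from compound 1 to compound 2 (0.24 log units; within the scatter), exchanged one six-membered aryl for another and stayed within the scatter; no measured step swaps the 2-hydroxy-5-methylphenyl for a five-membered ring. Compound 3 is therefore expected to move little, with a 1.6-fold higher number from compound 2 to compound 3 (0.21 log units; within the scatter) as the estimated step. The estimate for compound 3 is 12000 nM, within 4000 nM to 40000 nM.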

Compound 3, half-maximal inhibitory concentration: >= 40000 nM
Compound 3 ended at the assay's limit; the forecaster's own chance of this, stated with the estimate: 20%; middle value at least 3.3-fold (0.52 log units) from the limit.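

Compound 3 stands at a limit of this assay, not at a number: the limit of >= 40000 nM in this assay, at which 1 of the 3 values shown sits.

The exchange of one six-membered aromatic ring for another stayed within the scatter, but furan-2-yl on a carbon with a double bond to nitrogen gives an at least 5.4-fold higher number from compound 2 to compound 3 (0.73 log units; beyond the scatter) and an at least 3.1-fold higher number from compound 1 to compound 3 (0.49 log units; beyond the scatter). This position therefore responds to the group it carries.

Ring size and hydrogen-bond donor count change together in this swap, and the compounds shown do not separate them. On these data alone, it remains open whether an unsubstituted phenyl or a pyridin-2-yl ring would match compound 2.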